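This account rests on a few compounds, and the source may have more. Where it says the series, first, only, none or still open, it means among the compounds named here.

In a functional assay on aorta (Rattus norvegicus, strain Sprague-Dawley) (on this read-out higher numbers stand for an effect only at larger amounts of compound and lower numbers for an effect already at smaller amounts), the series offers little to build on. Compound 1 (`Cc1nn(-c2ccccc2)c2nc(O)c(-c3nc(N)cc(N)n3)cc12`) is recorded as "not determined" (no result reported). Compound 3 (`Cc1ccc(COc2nc3c(cc2-c2nc(N)cc(N)n2)c(C)nn3-c2ccccc2)cc1`) is also recorded as "not determined" (no result reported), so it has no number of its own to serve as a starting point. For the measured compounds named here, the only number comes from compound 2 (`Cc1nn(-c2ccccc2)c2nc(OCc3cccc(F)c3)c(-c3nc(N)cc(N)n3)cc12`), at 360 nM. Compound 4 (`Cc1nn(-c2ccccc2)c2nc(OCc3ccc(C(F)(F)F)cc3)c(-c3nc(N)cc(N)n3)cc12`) carries trifluoromethyl in place of methyl on an aromatic carbon, para to a large group, relative to compound 3 (trifluoromethyl in place of methyl on an aromatic carbon). Going by the values given here, no measured step shows what such a change does in this assay, so no shift beyond the usual scatter is expected from the sole reference, compound 2 at 360 nM. The expected value for compound 4 is 400 nM, with an estimated range of 120 nM to 1300 nM.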

Compound 4, half-maximal effective concentration: 1600 nM
Estimate against measurement, compound 4: 4.0-fold (0.60 log units) below; the whole stated range lies below it.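

In this assay the aryl end of the ether chain is not indifferent to its substitution: 4-(trifluoromethyl)phenyl in place of 3-fluorophenyl gives a 4.4-fold higher number from compound 2 to compound 4 (0.65 log units; beyond the scatter) and needs more compound for the effect. This step changes the substituent and its place on the ring together, so the two cannot be separated, and the change from methyl to trifluoromethyl cannot be read, since compound 3 has no number. No data at hand give a reason for the shift.

Still open, on these data alone, is how 4-fluorophenyl or 3-(trifluoromethyl)phenyl would read here. Also open, as far as these compounds go, is what a longer chain to the ring, or an amine on it, would do.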